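Adding a Second Hydroxy Group to a Phenol Ring

The compounds below may be only part of what the source reports. "The series", "measured", "known", "first", "only" and "open" are said of these compounds alone.

Compound 1, with the structure `Oc1ccc(C2CC(c3ccccc3O)=NN2c2cccc(Cl)c2)cc1F`, in an assay on U-937 cells for inhibition of protein kinase C zeta type (Homo sapiens), read by reporter gene assay (a lower number here means a stronger inhibitor, a higher number a weaker inhibitor), gives "not determined" (no result reported), so it has no single number there. Its closest measured relative is compound 2, with the structure `Oc1ccccc1C1=NN(c2cccc(Cl)c2)C(c2cc(F)c(O)c(F)c2)C1`, which in this assay gives 2500 nM. For the measured compounds named here, no step between compound 1 and compound 2 is available, so those two values show only that one of them stands at a moderate potency and the other has no number at all.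

Compound 3, with the structure `Oc1ccc(C2=NN(c3cccc(Cl)c3)C(c3ccc(O)c(F)c3)C2)c(O)c1`, differs from compound 1 by a single change: hydroxy in place of hydrogen on an aromatic carbon. In words, a hydroxy replaces a hydrogen on an aromatic carbon of a six-membered aromatic ring of carbon only, meta to a hydroxy group and para to a large group, turning a 2-hydroxyphenyl into a 2,4-dihydroxyphenyl. Without a measured step of this kind in this assay, the expected size of the change is uncertain, and no direction beyond the scatter can be claimed. Compound 3 is therefore expected to land near 2000 nM, within a range of 500 nM to 8000 nM.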

Compound 3, half-maximal inhibitory concentration: 1100 nM
Compound 3: the middle estimate sits 1.8-fold (0.26 log units) above what was measured; the measured number falls inside the stated range.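

In this assay, for the compounds shown here, compound 1 gives "not determined" (no result reported) while compound 3 gives 1100 nM so no step between these two compounds can be read. Going by these compounds, whether the hydroxy that turns a 2-hydroxyphenyl into a 2,4-dihydroxyphenyl strengthens or weakens inhibition stays open. No further data shown here bear on this result.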